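The compounds below may be only part of what the source reports. "The series", "measured", "known", "first", "only" and "open" are said of these compounds alone.

In a functional assay on U-937 cells (Homo sapiens) for antiproliferative activity, read by MTT assay, with a stated time of 24 h (on this read-out higher numbers stand for weaker inhibition and lower numbers for stronger inhibition), compound 2 `CCCCc1oc2ccccc2c1C(=O)c1ccc(OCC(=O)Nc2cccc(OC)c2)cc1` gives 24200 nM, level within the scatter with compound 1 `CCCCNC(=O)COc1ccc(C(=O)c2c(CCCC)oc3ccccc23)cc1` at 22800 nM. Compound 3 `CCCCc1oc2ccccc2c1C(=O)c1ccc(OCC(=O)N[C@H](C)c2ccccc2)cc1` differs from compound 2 on the same amide-type nitrogen: 1-phenylethyl in place of 3-methoxyphenyl on an amide-type nitrogen. Going by the values given here, the only measured step at this place, a 1.1-fold higher number from compound 1 to compound 2 (0.03 log units; within the scatter), exchanged butyl for 3-methoxyphenyl and stayed within the scatter. With just this one step to go on, no change beyond the scatter is expected in this assay, in either direction. The expected step is a 1.1-fold lower number from compound 2 to compound 3 (0.02 log units; within the scatter). Compound 3 is estimated at 23000 nM, with an expected range of 11000 nM to 48000 nM.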

Compound 3, half-maximal inhibitory concentration: 19800 nM
Compound 3: middle estimate off by 1.2-fold (0.07 log units), on the high side; low and high end bracket the measured number.
By their numbers in this assay, from the lowest: compounds 3, 1 and 2 (each within the scatter of the next).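

In this assay, the amide-type nitrogen accepts 1-phenylethyl, a group with a defined stereocentre, with no change beyond the scatter: a 1.2-fold lower number from compound 2 to compound 3 (0.09 log units; within the scatter), and a 1.2-fold lower number from compound 1 to compound 3 (0.06 log units; within the scatter). Butyl, 3-methoxyphenyl and 1-phenylethyl thus all sit level at this position. No evidence is available to account for this.

Going by these compounds, whether the mirror-image 1-phenylethyl group would read the same remains open. Also open, on these data alone, is whether a substituent on this nitrogen carrying an amine or a carboxylic acid would move the number beyond the scatter.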